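The source may report more compounds than this note shows. Statements on the series, on what has been measured and on what is new or still open speak of the compounds shown alone.

Compound 1 `O=C1NCCc2nc(C#Cc3cccc(F)c3)sc21`, compound 2 `CC(=O)N1CCc2nc(C#Cc3ccccc3)sc2C1`, compound 3 `CC1CCC(C(=O)N2CCc3nc(C#Cc4ccccc4)sc3C2)CC1`.

In an assay on HEK293 cells for negative allosteric modulation of metabotropic glutamate receptor 5 (Homo sapiens), read by FLIPR, with a stated time of 1 h (on this read-out lower numbers stand for stronger inhibition and higher numbers for weaker inhibition), compound 2 gives 90 nM. Compound 1 reaches only the assay limit, > 10000 nM. Compound 3 likewise stops at the limit, > 10000 nM. Compound 2 therefore stands as the sole numbered value among the three shown. Compound 4 `Cc1cccc(C(=O)N2CCc3nc(C#Cc4ccccc4)sc3C2)n1` differs from compound 2 at the carbonyl carbon: 6-methylpyridin-2-yl in place of methyl on a carbonyl carbon. For the measured compounds named here, the one measured step that bears on this place is an at least 110-fold higher number from compound 2 to compound 3 (2.04 log units; beyond the scatter), a large loss, with the limit of > 10000 nM in this assay, at which 2 of the 3 values shown sit, marking where compound 3 sits. A weakening beyond the scatter is thus expected for compound 4, though the two entering groups are not alike and the drop may be smaller. Compound 4 is estimated at 1500 nM, with a range from 200 nM to 10000 nM, meaning an expected step of a 17-fold higher number from compound 2 to compound 4 (1.22 log units; beyond the scatter).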

Compound 4, half-maximal inhibitory concentration: > 10000 nM
Compound 4: no number, only a limit; the forecaster's own chance of this, stated with the estimate: 35%; at least 6.6-fold (0.82 log units) between middle value and limit.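

With 6-methylpyridin-2-yl in place of methyl on the carbonyl carbon, the result is an at least 110-fold higher number from compound 2 to compound 4 (2.04 log units; beyond the scatter). The large loss at this place is therefore not tied to 4-methylcyclohexyl, since a group with a six-membered aromatic ring and a ring nitrogen brings it too. The step between compound 3 and compound 4 cannot be read, as both values are limits: the limit of > 10000 nM in this assay, at which 3 of the 4 values shown sit.

Left open is whether ethyl or cyclopropyl on the carbonyl carbon stays close to compound 2. Also open, from the compounds shown here alone, is where, beyond methyl, the loss sets in.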